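A few compounds are considered here, and "the series" means these few. Any claim that something is new, unique, unknown or untested is made for them only; others in the source may bear on it.

The series shares one core, a diaryl ether bearing a thiourea linked to a difluorophenyl group, and differs only at the amide on the pyridine. Compound 1 `CNC(=O)c1cc(Oc2cccc(NC(=S)Nc3ccc(F)c(F)c3)c2)ccn1` carries a methylamide and gives 30300 nM in a functional assay on HCT-116 cells (Homo sapiens) for cytotoxicity, read by MTT assay, with a stated time of 48 h; a lower number here means a stronger inhibitor, a higher number a weaker inhibitor. Going by the values given here, compound 2 `O=C(NC1CCCCC1)c1cc(Oc2cccc(NC(=S)Nc3ccc(F)c(F)c3)c2)ccn1` carries a cyclohexylamide and gives 8900 nM in this assay, the lowest of the two numbers so far; the step of a 3.4-fold lower number from compound 1 to compound 2 (0.53 log units; beyond the scatter) is the only measured step. Compound 3 `O=C(c1cc(Oc2cccc(NC(=S)Nc3ccc(F)c(F)c3)c2)ccn1)N1CCCC1` is not yet measured. The change from compound 2 to compound 3 is pyrrolidin-1-yl in place of cyclohexylamino on a carbonyl carbon. Among the compounds with values here, the one measured step concerns a larger group replacing a smaller one on a nitrogen that keeps its hydrogen, whereas here the ring nitrogen is built into the amide and loses its hydrogen; no measured step bears directly on that. Compound 3 is therefore expected near compound 2, with a step of a 1.3-fold higher number from compound 2 to compound 3 (0.13 log units; within the scatter) in this assay. Compound 3 is estimated at 12000 nM, within 5000 nM to 35000 nM.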

Compound 3, half-maximal inhibitory concentration: 52000 nM
For compound 3 the middle estimate is 4.3-fold (0.64 log units) below the measured one; measured number outside the range, above it.
By their numbers in this assay, from the lowest: compound 2; then compounds 1 and 3 (each within the scatter of the next).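

In this assay pyrrolidin-1-yl in place of cyclohexylamino on the carbonyl carbon gives a 5.8-fold higher number from compound 2 to compound 3 (0.77 log units; beyond the scatter) and so shows that this position responds to a change that removes the hydrogen-bond donor and replaces the six-membered ring with a five-membered one. Pyrrolidin-1-yl in place of methylamino gives a 1.7-fold higher number from compound 1 to compound 3 (0.23 log units; within the scatter) and leaves compound 3 and compound 1 within the scatter of each other, so that among these three only compound 2 stands clear of the others. No measurement available here explains the difference.

The compounds shown do not separate the loss of the amide hydrogen from the change of ring: a cyclopentylamino group would keep that hydrogen on a five-membered ring, while a piperidin-1-yl group would lack it on a six-membered ring. From the compounds shown here alone, how a morpholine ring or a longer alkyl chain would behave at this carbonyl carbon also remains open.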